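Cytotoxicity of Schiff-base thiazoles: from chlorophenyl to nitrophenyl

A few compounds are considered here, and "the series" means these few. Any claim that something is new, unique, unknown or untested is made for them only; others in the source may bear on it.

Measured compounds:
compound 1, `Clc1ccc(/C=N/c2sc3c(c2-c2nc4ccccc4s2)CCCC3)cc1`, 367 ug/mL in an ADME assay on cells (Rhabdomyosarcoma cell, Homo sapiens) for cytotoxicity, read by MTT assay, with a stated time of 72 h; on this read-out higher numbers stand for lower toxicity in this test and lower numbers for higher toxicity in this test
compound 2, `Clc1ccccc1/C=N/c1sc2c(c1-c1nc3ccccc3s1)CCCC2`, 332 ug/mL in this assay

Compound 2 stands lowest of the two numbers, with compound 1 nearest at a 1.1-fold lower number from compound 1 to compound 2 (0.04 log units; within the scatter), so the two values cannot be told apart. Among the compounds with values here, the only measured step, a 1.1-fold lower number from compound 1 to compound 2 (0.04 log units; within the scatter), concerns a shift of the chlorine on the phenyl ring and lies within the scatter.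

Compound 3, `O=[N+]([O-])c1ccc(/C=N/c2sc3c(c2-c2nc4ccccc4s2)CCCC3)cc1`, is not yet measured. It differs from compound 2 as follows: 4-nitrophenyl in place of 2-chlorophenyl on a carbon with a double bond to nitrogen. Within the data shown here, no measured pair exchanges a chlorine for a nitro group, so the step from compound 1 to compound 2 bears on it only loosely: it shows that one change on this phenyl ring left the number essentially where it was. Among the measured compounds shown here, the nitro group is a different substituent, and nothing among the measured compounds tells how it behaves here, so a step beyond the scatter in either direction cannot be ruled out.

On that basis compound 3 is expected to give 300 ug/mL in this assay, within 150 ug/mL to 600 ug/mL, which corresponds to an expected step of a 1.1-fold lower number from compound 2 to compound 3 (0.04 log units; within the scatter).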

Compound 3, half-maximal cytotoxic concentration: 316 ug/mL
The estimate for compound 3 lay 1.1-fold (0.02 log units) below the measured number; the measured number falls inside the stated range.
By their numbers in this assay, from the lowest: compounds 3, 2 and 1 (each within the scatter of the next).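

The exchange of the group itself, which the earlier pair could not address, can now be read directly in this assay: nitro in place of chloro on an aromatic carbon gives a 1.2-fold lower number from compound 1 to compound 3 (0.06 log units; within the scatter), so the two groups cannot be told apart here. The larger change, 4-nitrophenyl in place of 2-chlorophenyl, which alters both the group and where it sits on the phenyl ring, gives a 1.1-fold lower number from compound 2 to compound 3 (0.02 log units; within the scatter), and this too stays inside the scatter. On a carbon with a double bond to nitrogen, then, the three aryl groups shown give numbers that cannot be separated, although the 4-nitrophenyl group counts hydrogen-bond acceptors and adds heavy atoms that the chlorophenyl groups lack. No supporting data bear on why these numbers stay together.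

The compounds shown leave open whether a group of another kind on this phenyl ring, such as an amine or a carboxylic acid, would take the number beyond the scatter. They also leave open whether this flat picture would hold with the phenyl ring replaced by a longer chain or with a change elsewhere on the shared core.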